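From pyrazin-2-yl to 3-chlorophenyl: an expected gain

The source may hold more compounds than are shown below. What is called first, only, known or untested is meant among the compounds shown, and "the series" means these compounds.

Compound 1 `Cc1nn(-c2nc(-c3ccc(Cl)c(Cl)c3)c(SC(C)C)s2)c(C(=O)O)c1-c1cnccn1` gives 14000 nM in a functional assay on BJAB cells (Homo sapiens) for antiproliferative activity, with a stated time of 4 days (a lower number here means that less compound is needed, a higher number that more compound is needed for the effect), the highest number among the three measured compounds, with both steps away from it beyond the scatter. Compound 2 `COc1cc(C#N)cc(-c2c(C)nn(-c3nc(-c4ccc(Cl)c(Cl)c4)c(SC(C)C)s3)c2C(=O)O)c1` gives 5200 nM in this assay, and compound 3 `Cc1cc(Cl)cc(-c2c(C)nn(-c3nc(-c4ccc(Cl)c(Cl)c4)c(SC(C)C)s3)c2C(=O)O)c1` gives 663 nM. The measured steps from compound 1 both lower the number: a 2.7-fold lower number from compound 1 to compound 2 (0.43 log units; beyond the scatter) and a 21-fold lower number from compound 1 to compound 3 (1.32 log units; beyond the scatter). Between the two six-membered aromatic rings of carbon only, a 7.8-fold lower number from compound 2 to compound 3 (0.89 log units; beyond the scatter).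

Compound 4 `Cc1nn(-c2nc(-c3ccc(Cl)c(Cl)c3)c(SC(C)C)s2)c(C(=O)O)c1-c1cccc(Cl)c1` differs from compound 1 in one place: 3-chlorophenyl in place of pyrazin-2-yl on an aromatic carbon. Both measured steps bear on this change, since each also replaces pyrazin-2-yl with a six-membered aromatic ring of carbon only on the same aromatic carbon. The 3-chlorophenyl group carries the chlorine of 3-chloro-5-methylphenyl but not its methyl group, so the step is expected to be large but short of the step seen for compound 3, which was a 21-fold lower number from compound 1 to compound 3 (1.32 log units; beyond the scatter). For compound 4 a step of a 9.3-fold lower number from compound 1 to compound 4 (0.97 log units; beyond the scatter) is therefore expected. Compound 4 is estimated to give 1500 nM in this assay, within a range of 500 nM to 5000 nM.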

Compound 4, half-maximal effective concentration: 13600 nM
Compound 4: the middle estimate sits 9.1-fold (0.96 log units) below what was measured; the measured number lies above the stated range.
By their numbers in this assay, from the lowest: compound 3; then compound 2; then compounds 4 and 1 (each within the scatter of the next).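

Within this assay, the swap of pyrazin-2-yl for 3-chlorophenyl on its own leaves the number unchanged within the scatter, with a 1.0-fold lower number from compound 1 to compound 4 (0.01 log units; within the scatter), so a ring of carbon only at this position is not enough for a gain. The methyl group of 3-chloro-5-methylphenyl matters far more than the chlorine alone among these compounds: hydrogen in place of that methyl gives a 21-fold higher number from compound 3 to compound 4 (1.31 log units; beyond the scatter), which undoes the whole gain seen over pyrazin-2-yl. The change to 3-chlorophenyl from 3-cyano-5-methoxyphenyl gives a 2.6-fold higher number from compound 2 to compound 4 (0.42 log units; beyond the scatter), so both rings with two groups give lower numbers than the ring with chlorine alone.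

Nothing shown accounts for this dependence on the methyl group. On these data alone, it remains open whether 3-methylphenyl without chlorine would keep the gain, and whether an ethyl group or an amine could stand in for that methyl.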